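Working notes on a chloro-to-methoxy swap in one series

This account rests on a few compounds, and the source may have more. Where it says the series, first, only, none or still open, it means among the compounds named here.

Measured compounds, read in an assay on isolated protein for inhibition of Dihydrofolate reductase (Homo sapiens), read by spectrophotometry, using NADPH, with stated times of 5 s and 6 min, tested at 5 uM; a higher number here means a stronger effect of the compound at the concentration tested, a lower number a weaker effect:
Compound 1 `COc1ccc(OCCCON2C(N)=NC(N)=NC23CCOCC3)cc1` gives > 90%, which is a limit of the assay and not a number.
Compound 2 `NC1=NC2(CCOCC2)N(OCCCOc2ccc(Cl)cc2)C(N)=N1` gives > 90%, likewise a limit.
Compound 3 `NC1=NC2(CCSCC2)N(OCCCOc2ccc(Cl)cc2)C(N)=N1` gives > 90%, again a limit.

Compound 2 and compound 1 share a core and differ by methoxy in place of chloro on an aromatic carbon. The step that the two limits leave unreadable from compound 2 to compound 1 cannot be sized, since both values sit at the limit of > 90% in this assay, at which 3 of the 3 values shown sit; no order between the two compounds can be read from this.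

Compound 3 carries a different core from compound 2; the difference between the two cores is not broken down here. Within the scatter of this assay compound 3 sits where compound 2 and compound 1 sit, at the limit.

Compound 4 `COc1ccc(OCCCON2C(N)=NC(N)=NC23CCSCC3)cc1` has not yet been measured. It differs from compound 3 by methoxy in place of chloro on an aromatic carbon, the same change as from compound 2 to compound 1, at the same place on the ring.

For this assay the expected step is a step that the limit leaves unreadable from compound 3 to compound 4, resting on the fact that compound 1, compound 2 and compound 3 all sit at the limit of > 90% in this assay, at which 3 of the 3 values shown sit, so the change is not expected to pull the read-out off that limit. Compound 4 is accordingly estimated at 93%, with a likely range from 84% to 99%, and most probably reported once more as a limit rather than as a number.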

Compound 4, a percentage reported as inhibition, at one concentration (the size of the read-out at that concentration, not a potency): 81.3%
The estimate for compound 4 lay 11.7 percentage points above the measured number, and the stated range ends above it.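

In this assay, carrying methoxy in place of chloro onto the core of compound 3 gives a number at least 8.7 percentage points lower from compound 3 to compound 4 (that floor lies within the scatter), and compound 4, at 81.3%, is the only compound shown that reads as a number. From the compounds shown here alone, that printed floor does not establish a real loss on this core, and the full size of the step stays unknown, since the starting value is a limit and not a number. The same swap on the core of compound 2 cannot be read, so nothing shows whether the change behaves alike or differently on the two cores, as both ends of that step are limits: the limit of > 90% in this assay, at which 3 of the 4 values shown sit.

The compounds shown carry only chloro or methoxy at this place on the aromatic ring, which leaves open how a fluoro, a nitrile or an amine there would read on either core. Also open, going by these compounds, are the effect of a longer chain between the aromatic ring and the core, and whether the compounds now at the limit would separate from one another in a full concentration series.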